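The source may report more compounds than this note shows. Statements on the series, on what has been measured and on what is new or still open speak of the compounds shown alone.

Of the compounds shown here, three with a shared core have been measured in a functional assay (trachea) with Cavia porcellus as the target; on this read-out higher numbers stand for weaker inhibition and lower numbers for stronger inhibition. Compound 1 `CCCCCCCCn1nc(-c2cccnc2)c2ccccc2c1=O` gives 21900 nM. Compound 2 `C=CCn1nc(-c2cccnc2)c2ccccc2c1=O` gives 2140 nM, and compound 3 `O=c1c2ccccc2c(-c2cccnc2)nn1Cc1ccccc1` gives 2450 nM. On these numbers compound 3 stands second highest of three, close to compound 2 and well apart from compound 1.

The next compound, compound 4 `O=c1c2ccccc2c(-c2cccnc2)nn1CCSc1ccccc1`, is reached from compound 3 by one change: (phenylsulfanyl)methyl in place of phenyl on a saturated chain carbon bound to an aromatic nitrogen.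

Among the measured compounds shown here, two measured steps touch the same place. The step of an 8.9-fold lower number from compound 1 to compound 3 (0.95 log units; beyond the scatter) shows that replacing the long heptyl chain with phenyl lowered the number markedly, and the step of a 1.1-fold higher number from compound 2 to compound 3 (0.06 log units; within the scatter) shows that phenyl and vinyl at this place give numbers within the scatter of each other. Compound 4 carries a longer group again, with a sulfur-bearing chain between the nitrogen and the phenyl, which moves it partway back toward the pattern of compound 1. A small to moderate rise in this assay is therefore expected, as a 1.8-fold higher number from compound 3 to compound 4 (0.26 log units; within the scatter), though a value within the scatter of compound 3 would not be surprising. Compound 4 is estimated at 4500 nM, with a likely range from 1500 nM to 14000 nM.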

Compound 4, half-maximal inhibitory concentration: 9120 nM
Compound 4: middle estimate off by 2.0-fold (0.31 log units), on the low side; measured number inside the range.
By their numbers in this assay, from the lowest: compounds 2 and 3 (each within the scatter of the next); then compound 4; then compound 1.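

In this assay, among the compounds shown here, the earlier compounds showed phenyl and vinyl at this position giving numbers within the scatter of each other, but this position does not accept every group that carries a phenyl ring equally: (phenylsulfanyl)methyl gives a 3.7-fold higher number from compound 3 to compound 4 (0.57 log units; beyond the scatter) and a 4.3-fold higher number from compound 2 to compound 4 (0.63 log units; beyond the scatter). The loss is only partial, since the result also shows a 2.4-fold lower number from compound 1 to compound 4 (0.38 log units; beyond the scatter), which places compound 4 between the pair of compound 2 and compound 3 and the long-chain compound 1. No measurement shown gives a reason for these shifts.

The compounds shown leave open whether the sulfur atom or the longer link matters more, a question that an oxygen atom or a plain carbon chain in place of the sulfur could settle. From the compounds shown here alone, how an amine or a carboxylic acid at the end of the chain would read here also remains open.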